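From Bromo to Phenyl: Expecting Little Change in Growth Inhibition

This account rests on a few compounds, and the source may have more. Where it says the series, first, only, none or still open, it means among the compounds named here.

The measured compounds in a functional assay on ASPC1 cells (Homo sapiens) for inhibition, read by MTT assay, with a stated time of 72 h (a higher number here means a weaker inhibitor of growth, a lower number a stronger inhibitor of growth), are:
compound 1 `CC(C)(C)c1ccc(CNCCCNS(=O)(=O)c2cc(C(F)(F)F)cc(C(F)(F)F)c2)cc1` gives 2700 nM
compound 2 `O=S(=O)(NCCCNCc1ccccc1)c1cc(C(F)(F)F)cc(C(F)(F)F)c1` gives 13000 nM
compound 3 `O=S(=O)(NCCCNCc1ccc(Br)cc1)c1cc(C(F)(F)F)cc(C(F)(F)F)c1` gives 2800 nM

Compound 3 stands second highest of the three numbers. Its value sits nearest that of compound 1, with a 1.0-fold higher number from compound 1 to compound 3 (0.02 log units; within the scatter), and furthest from that of compound 2, with a 4.6-fold lower number from compound 2 to compound 3 (0.67 log units; beyond the scatter).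

Compound 4 `O=S(=O)(NCCCNCc1ccc(-c2ccccc2)cc1)c1cc(C(F)(F)F)cc(C(F)(F)F)c1` differs from compound 3 in one place: phenyl in place of bromo on an aromatic carbon. For the measured compounds named here, the steps that bear on this change are the ones that alter the same aromatic carbon. Removing the tert-butyl of compound 1 gave a 4.8-fold higher number from compound 1 to compound 2 (0.68 log units; beyond the scatter), while putting a bromo onto compound 2 gave a 4.6-fold lower number from compound 2 to compound 3 (0.67 log units; beyond the scatter), and tert-butyl against bromo gave a 1.0-fold higher number from compound 1 to compound 3 (0.02 log units; within the scatter). Two different groups at this carbon thus landed close together, with only the unsubstituted compound 2 set apart. A third group at the same carbon is therefore expected to leave the number near that of compound 3, with the estimated step being a 1.3-fold lower number from compound 3 to compound 4 (0.10 log units; within the scatter). Compound 4 is expected to give about 2200 nM in this assay, within a range from 700 nM to 7000 nM.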

Compound 4, concentration for 50% growth inhibition: 2500 nM
Compound 4: the middle estimate sits 1.1-fold (0.06 log units) below what was measured; low and high end bracket the measured number.
By their numbers in this assay, from the lowest: compounds 4, 1 and 3 (each within the scatter of the next); then compound 2.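

In this assay, a phenyl ring took the place of the lone bromine with a 1.1-fold lower number from compound 3 to compound 4 (0.05 log units; within the scatter), and the comparison with the tert-butyl compound gave a 1.1-fold lower number from compound 1 to compound 4 (0.03 log units; within the scatter), so three quite different groups at this aromatic carbon now stand within the scatter of one another. Against the unsubstituted compound, phenyl gave a 5.2-fold lower number from compound 2 to compound 4 (0.72 log units; beyond the scatter), which shows that the gap from hydrogen seen with bromo and tert-butyl also holds for a full aromatic ring. No measurement offered here accounts for this shared level of growth inhibition.

As far as these compounds go, whether an amine or a carboxylic acid at this carbon would stay with compound 1, compound 3 and compound 4 or fall back toward compound 2 remains open. Also open, from the compounds shown here alone, is whether a group as small as fluoro or methyl would already be enough to close that gap.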